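Chain-extended fluorobenzamide analogue in the melanoma cytotoxicity series

This account rests on a few compounds, and the source may have more. Where it says the series, first, only, none or still open, it means among the compounds named here.

Measured compounds:
compound 1 `O=S(=O)(NCCNc1nccc(-c2c(-c3cccc(F)c3)nc3sccn23)n1)c1ccc(Br)cc1`: 13500 nM
compound 2 `O=S(=O)(NCCNc1nccc(-c2c(-c3cccc(F)c3)nc3sccn23)n1)c1ccccc1`: 19000 nM
compound 3 `O=C(NCCNc1nccc(-c2c(-c3cccc(F)c3)nc3sccn23)n1)c1ccccc1`: 17000 nM

In a functional assay on SK-MEL-28 cells (Homo sapiens) for cytotoxicity, read by MTT assay (a higher number here means a weaker inhibitor, a lower number a stronger inhibitor), compound 3 gives 17000 nM, which places it second highest of the three numbers; its nearest neighbour is compound 2 and its furthest is compound 1, with both gaps within the scatter. The unmeasured compound 4 `O=C(NCCCNc1nccc(-c2c(-c3cccc(F)c3)nc3sccn23)n1)c1ccc(F)cc1` differs from compound 3 by (((4-fluorophenyl)carbonyl)amino)methyl in place of benzamido on a saturated chain carbon, two bonds along the chain from a nitrogen on an aromatic ring.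

Going by the values given here, two measured steps bear on this change. Replacing the aromatic substituent with hydrogen gave a 1.4-fold higher number from compound 1 to compound 2 (0.15 log units; within the scatter), and exchanging the sulfonyl for a benzoyl on the amine nitrogen gave a 1.1-fold lower number from compound 2 to compound 3 (0.05 log units; within the scatter). Every change so far at the amide end of the chain has thus left the number where it was. Among the compounds with values here, no measured pair tests the lengthened chain itself, so that part of the change carries no evidence either way.

For compound 4 the expected outcome in this assay is therefore no step beyond the scatter, an estimate of no change at the digits printed from compound 3 to compound 4 (within the scatter). The estimated value for compound 4 is 17000 nM, with a range from 8000 nM to 36000 nM.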

Compound 4, half-maximal inhibitory concentration: > 20000 nM
Compound 4 was reported as a limit; the forecaster's own chance of this, stated with the estimate: 10%; at least 1.1-fold (0.07 log units) between middle value and limit.
By their numbers in this assay, from the lowest: compounds 1, 3 and 2 (each within the scatter of the next). At a limit, above all of these: compound 4.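

In this assay compound 4 stands only as a limit, not a number: the limit of > 20000 nM in this assay, at which 1 of the 4 values shown sits. Read as floors, an at least 1.1-fold higher number from compound 3 to compound 4 (0.07 log units; that floor lies within the scatter), an at least 1.0-fold higher number from compound 2 to compound 4 (0.02 log units; that floor lies within the scatter) and an at least 1.4-fold higher number from compound 1 to compound 4 (0.17 log units; that floor lies within the scatter), so each step may be small or large and none is shown to pass the scatter. On these data alone, what is new is direction only: the (((4-fluorophenyl)carbonyl)amino)methyl change, the only one here that alters the chain, gives no number lower than those of compounds 1, 2 and 3, and its true size stays unknown.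

Open, as far as these compounds go, is which part of the change matters, the longer chain or the fluorine of the 4-fluorophenyl group, as both arrive together in compound 4. Also open, from the compounds shown here alone, is how a still longer chain, or an amine or a carboxylic acid at the chain end, would read in this assay.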